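The source may report more compounds than this note shows. Statements on the series, on what has been measured and on what is new or still open speak of the compounds shown alone.

Of the compounds shown here, three built on one shared core have been measured in an assay on isolated protein for agonist activity at prostaglandin E2 receptor EP3 subtype (Homo sapiens); a lower number here means that less compound is needed, a higher number that more compound is needed for the effect. Compound 1 `CCCCC1([C@H](O)/C=C/[C@H]2COC(=O)N2CCSc2nc(C(=O)O)cs2)CCC1` gives 3.9 nM. Compound 2 `CC(C)(C)CCC1([C@H](O)/C=C/[C@H]2COC(=O)N2CCSc2nc(C(=O)O)cs2)CCC1` gives 6.7 nM, and compound 3 `CC(C)(CCCCF)[C@H](O)/C=C/[C@H]1COC(=O)N1CCSc1nc(C(=O)O)cs1` gives 4.7 nM. Compound 2 holds the highest of the three numbers, but its separation from either neighbour stays inside the usual scatter: the step reads a 1.7-fold higher number from compound 1 to compound 2 (0.24 log units; within the scatter) on one side and a 1.4-fold lower number from compound 2 to compound 3 (0.15 log units; within the scatter) on the other, so the three compounds cannot be ranked against each other on these numbers.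

Compound 4 `O=C(O)c1csc(SCCN2C(=O)OC[C@@H]2/C=C/[C@@H](O)C2(CCc3ccccc3)CCC2)n1` has not yet been measured in this assay. It differs from compound 2 by phenyl in place of tert-butyl on a saturated chain carbon, two bonds along the chain from a saturated ring carbon. The step that bears most directly on this change is the one at the same place, where a tert-butyl took the place of an ethyl, a 1.7-fold higher number from compound 1 to compound 2 (0.24 log units; within the scatter), a shift that stayed within the scatter. The exchange of the whole side chain, a 1.4-fold lower number from compound 2 to compound 3 (0.15 log units; within the scatter), was likewise within the scatter. Within the data shown here, nothing measured so far shows that changes at this position move the number beyond the scatter, so for compound 4 the expected step is a 1.2-fold lower number from compound 2 to compound 4 (0.09 log units; within the scatter), with no clear direction. Compound 4 is therefore estimated at 5.5 nM, within a range from 2 nM to 15 nM.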

Compound 4, half-maximal effective concentration: 27 nM
For compound 4 the middle estimate is 4.9-fold (0.69 log units) below the measured one; the measured number lies above the stated range.
By their numbers in this assay, from the lowest: compounds 1, 3 and 2 (each within the scatter of the next); then compound 4.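

Among these compounds, the end of this side chain is not indifferent in this assay: phenyl in place of tert-butyl, on a saturated chain carbon, two bonds along the chain from a saturated ring carbon, gives a 4.0-fold higher number from compound 2 to compound 4 (0.61 log units; beyond the scatter), the first step at this place to lie beyond the scatter. Phenyl in place of ethyl at the same place gives a 6.9-fold higher number from compound 1 to compound 4 (0.84 log units; beyond the scatter), whereas the earlier exchange of ethyl for tert-butyl there stayed within the scatter, so among compound 1, compound 2 and compound 4 only the phenyl end separates from the others. No measurement among those shown explains why phenyl differs from these two saturated ends.

A cyclohexyl at this place would help show whether the higher number goes with any six-membered ring or specifically with an aromatic one, while a pyridyl would test a ring nitrogen in place of one ring carbon. Benzyl and 3-phenylpropyl in place of the phenethyl chain would show whether moving the phenyl closer to or further from the shared core changes the number.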